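Amide variation on the shared core: compound 2 to compound 3

The source may report more compounds than this note shows. Statements on the series, on what has been measured and on what is new or still open speak of the compounds shown alone.

Compound 2 `Cc1cccc(C(=O)Nc2ccc3[nH]cc(C4CCN(C)CC4)c3n2)c1` gives 490 nM in an assay for binding affinity to 5-hydroxytryptamine receptor 1D (Homo sapiens), read by radioligand binding (on this read-out higher numbers stand for weaker inhibition and lower numbers for stronger inhibition), the highest of the two numbers in hand. Compound 1 `CC(=O)Nc1cc2c(C3CCN(C)CC3)c[nH]c2cn1` gives 39 nM in this assay, and the gap between compound 1 and compound 2 lies beyond the scatter, so compound 1 is the stronger binder of the pair. Going by the values given here, no single-point step between measured compounds is available, so the effect of changing the group on the carbonyl has not been isolated directly.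

Compound 3 `CN1CCC(c2c[nH]c3ccc(NC(=O)c4cccs4)nc23)CC1` has not yet been measured. It differs from compound 2 in one place: thiophen-2-yl in place of 3-methylphenyl on a carbonyl carbon. Among the compounds with values here, the group on the carbonyl becomes smaller in compound 3 than in compound 2, and the only other measured compound, compound 1, with a smaller group on the carbonyl, sits at 39 nM. On that basis a step toward lower numbers is expected, of modest size, a 2.5-fold lower number from compound 2 to compound 3 (0.39 log units; beyond the scatter), though it may not exceed the scatter. For compound 3 the expected value in this assay is 200 nM, with a range from 70 nM to 600 nM.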

Compound 3, inhibition constant: 650 nM
The estimate for compound 3 lay 3.3-fold (0.51 log units) below the measured number; measured number outside the range, above it.
By their numbers in this assay, from the lowest: compound 1; then compounds 2 and 3 (each within the scatter of the next).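

In this assay, going by these compounds alone, the change to thiophen-2-yl in place of 3-methylphenyl on a carbonyl carbon gives a 1.3-fold higher number from compound 2 to compound 3 (0.12 log units; within the scatter) and is the first single-place step available for the group on this carbonyl. Within this pair, the move from a six-membered aromatic ring of carbon only to a five-membered aromatic ring with 1 hetero atom, with 5 heavy atoms in place of 7 and 1 hydrogen-bond acceptor in place of 0, leaves the two values within the scatter of each other. The data on hand offer no measurement that would explain this outcome.

On these data alone, only these two aromatic groups can be compared on the core of compound 2, so it remains open whether a cyclohexyl ring, a longer alkyl chain or an amine-bearing chain on the carbonyl would give a step beyond the scatter. Compound 1, at 39 nM, differs from compound 2 and compound 3 in more than one place, so its value cannot be assigned to the group on the carbonyl alone.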